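This account rests on a few compounds, and the source may have more. Where it says the series, first, only, none or still open, it means among the compounds named here.

Compound 1 `COC(=O)C1=C(C)NC(=O)NC1c1cccs1` and compound 2 `CC1=C(C(=O)OCc2ccccc2)C(c2cccs2)NC(=O)N1` share a core and were both tested in an assay on membranes from HeLa cells for displacement of a labelled ligand from adenosine receptor A3 (Homo sapiens), read by scintillation counting, with a stated time of 180 min, tested at 1 uM; a higher number here means more inhibition at the concentration tested (going by the name of the read-out), a lower number less inhibition. In this assay compound 1 gives 3%, the lowest of the two numbers, and compound 2 gives 8%. The step between them is a number 5 percentage points higher from compound 1 to compound 2 (within the scatter). Going by the values given here, that is the only step measured so far, and it concerns phenyl in place of hydrogen on a saturated chain carbon bound to an oxygen next to a carbonyl group, a different part of the molecule from the change now in question.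

Compound 3 `COC(=O)C1=C(C)N(C)C(=O)NC1c1cccs1` differs from compound 1 by methyl in place of hydrogen on an amide-type nitrogen in a ring. Among the compounds with values here, no measured step touches this amide-type nitrogen in a ring, so the numbers so far give no pointer to a change in either direction beyond the scatter. The step of a number 2 percentage points higher from compound 1 to compound 3 (within the scatter) is therefore expected to be small. For compound 3 the estimate is 5%, with a range from -10% to 20%.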

Compound 3, a percentage reported as inhibition, at one concentration (the size of the read-out at that concentration, not a potency): 15%
Compound 3: the middle estimate sits 10 percentage points below what was measured; the measured number falls inside the stated range.
By their numbers in this assay, from the lowest: compounds 1, 2 and 3 (each within the scatter of the next, the first and the last beyond it).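

In this assay, going by these compounds alone, methyl in place of hydrogen on the amide-type nitrogen in a ring gives a number 12 percentage points higher from compound 1 to compound 3 (beyond the scatter), the only step so far that lies beyond the scatter. This shows that the hydrogen on this nitrogen is not needed for the read-out, and that a change at this position can shift the number more than the step at the ester did. Even so, compound 3 gives only 15% at a single concentration, which is a small read-out and not a potency, and nothing available accounts for the rise.

Going by these compounds, it remains open whether a longer chain such as ethyl, or a chain ending in an amine, on this nitrogen would move the number further. On these data alone, it is also open whether the methyl step would hold on the core of compound 2.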